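The compounds below may be only part of what the source reports. "The series", "measured", "known", "first", "only" and "open" are said of these compounds alone.

Working notes on the series. In an assay on CHO-K1 cells for displacement of a labelled ligand from melanin-concentrating hormone receptor 1 (Homo sapiens), read by scintillation proximity assay, with a stated time of 2 h (on this read-out lower numbers stand for stronger inhibition and higher numbers for weaker inhibition), compound 1 `Cc1ccc(/C=C/C(=O)Nc2ccc3nc(N4CCC(O)(C5CC5)CC4)nc(C)c3c2)cc1` gives 344 nM, compound 2 `C/C(=C\C(=O)Nc1ccc2nc(N3CCC(O)(C4CC4)CC3)nc(C)c2c1)c1ccc(Cl)cc1` gives 532 nM, and compound 3 `Cc1nc(N2CCC(N3CCOC3=O)CC2)nc2ccc(NC(=O)/C=C/c3ccc(OC(F)(F)F)cc3)cc12` gives 41 nM. Compound 3 stands lowest of the three on this read-out, with compound 1 nearest and compound 2 furthest, both beyond the scatter. Among the measured compounds shown here, the one measured step, a 1.5-fold higher number from compound 1 to compound 2 (0.19 log units; within the scatter), concerns the amide-side substituent, not the saturated ring, so no measured step bears on the change considered here.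

Compound 4 `Cc1nc(N2CCC(N3CCNC3=O)CC2)nc2ccc(NC(=O)/C=C/c3ccc(OC(F)(F)F)cc3)cc12` differs from compound 3 by 2-oxoimidazolidin-1-yl in place of 2-oxo-1,3-oxazolidin-3-yl on a saturated ring carbon. For the measured compounds named here, with no comparable step in the set, a change of little size is expected, a 1.1-fold higher number from compound 3 to compound 4 (0.04 log units; within the scatter), in no clear direction. Compound 4 is estimated at 45 nM, with a range from 15 nM to 140 nM.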

Compound 4, half-maximal inhibitory concentration: 66 nM
Estimate against measurement, compound 4: 1.5-fold (0.17 log units) below; the measured number falls inside the stated range.
By their numbers in this assay, from the lowest: compounds 3 and 4 (each within the scatter of the next); then compounds 1 and 2 (each within the scatter of the next).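

Among the compounds shown here, on a saturated ring carbon of the six-membered ring, 2-oxoimidazolidin-1-yl in place of 2-oxo-1,3-oxazolidin-3-yl gives a 1.6-fold higher number from compound 3 to compound 4 (0.21 log units; within the scatter) in this assay at this position, the first reading of a change here. The entering group carries a hydrogen-bond donor where the leaving group carries none, yet the step stays within the scatter. Nothing on hand accounts for this result.

Left open is how a primary amine or a carboxylic acid on the same ring carbon would read. Also open, on these data alone, is whether this exchange reads the same with a different amide-side group.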